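Aminoquinoxaline series: benzylamino in place of dichlorophenoxy

This account rests on a few compounds, and the source may have more. Where it says the series, first, only, none or still open, it means among the compounds named here.

Compound 1 `Nc1cc(N)c2nc(-c3ccccc3)c(Oc3ccc(Cl)c(Cl)c3)nc2c1` gives 5620 nM in a functional assay on SK-MEL-2 cells (Homo sapiens) for inhibition, read by sulforhodamine B assay, with a stated time of 48 h (on this read-out higher numbers stand for weaker inhibition of growth and lower numbers for stronger inhibition of growth), the lowest of the three numbers shown. Compound 2 `COc1cc(CNc2nc3cc(N)cc(N)c3nc2-c2ccccc2)cc(OC)c1OC` gives 16200 nM in this assay, and compound 3 `CCOC(=O)[C@H](CCC(=O)O)NC(=O)c1ccc(Oc2nc3cc(N)cc(N)c3nc2-c2ccccc2)cc1` gives 40700 nM; both gaps from compound 1 lie beyond the scatter. Within the data shown here, no one-point step between measured compounds is available. Compound 4 `Nc1cc(N)c2nc(-c3ccccc3)c(NCc3ccc(F)cc3)nc2c1` differs from compound 1 by (4-fluorobenzyl)amino in place of 3,4-dichlorophenoxy on an aromatic carbon. The expected step from compound 1 to compound 4 is a 1.8-fold higher number from compound 1 to compound 4 (0.25 log units; within the scatter), a modest loss, leaning weaker because compound 2 gives 16200 nM. Compound 4 is therefore estimated at 10000 nM, within 3000 nM to 35000 nM.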

Compound 4, concentration for 50% growth inhibition: 5250 nM
The estimate for compound 4 lay 1.9-fold (0.28 log units) above the measured number; the range from low to high includes it.
By their numbers in this assay, from the lowest: compounds 4 and 1 (each within the scatter of the next); then compound 2; then compound 3.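

At this position, on an aromatic carbon next to the ring nitrogen, (4-fluorobenzyl)amino in place of 3,4-dichlorophenoxy gives a 1.1-fold lower number from compound 1 to compound 4 (0.03 log units; within the scatter) in this assay. The exchange of the whole group, which adds a hydrogen-bond donor, therefore leaves the read-out within the scatter. No measurement shown bears on why the two groups read alike.

Still open, on these data alone, is whether this holds for an unsubstituted benzylamino group or a longer chain between the nitrogen and the aromatic ring. A morpholine or a carboxylic acid at this position also remains untested among the compounds shown.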